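Swapping an aryl sulfonate for a trifluoropropyl sulfonate

A few compounds are considered here, and "the series" means these few. Any claim that something is new, unique, unknown or untested is made for them only; others in the source may bear on it.

Measured so far:
compound 1 `CNC(=O)/C=C1/COc2cc(OS(=O)(=O)c3cccc(C#N)c3)ccc21`: 19 nM
compound 2 `CNC(=O)/C=C1/COc2cc(OS(=O)(=O)c3ccc([N+](=O)[O-])cc3)ccc21`: 37 nM

Both were tested in an assay (strain Sprague-Dawley) for inhibition of Amine oxidase [flavin-containing] A (Rattus norvegicus), read by spectrophotometry, with a stated time of 5 min; on this read-out higher numbers stand for weaker inhibition and lower numbers for stronger inhibition. Among the measured compounds shown here, compound 2 has the highest number of the two, and the only measured step, a 1.9-fold higher number from compound 1 to compound 2 (0.29 log units; within the scatter), stays within the scatter. Compound 3 `CNC(=O)/C=C1/COc2cc(OS(=O)(=O)CCC(F)(F)F)ccc21` differs from compound 2 as follows: 3,3,3-trifluoropropyl in place of 4-nitrophenyl on a sulfonyl sulfur. For the measured compounds named here, no measured step bears on a ring-to-chain exchange on a sulfonyl sulfur, so the outcome is open. Compound 3 is expected to give about 60 nM, a step of a 1.6-fold higher number from compound 2 to compound 3 (0.21 log units; within the scatter), with a range from 15 nM to 250 nM.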

Compound 3, half-maximal inhibitory concentration: 9.1 nM
Estimate against measurement, compound 3: 6.6-fold (0.82 log units) above, and the stated range ends above it.
By their numbers in this assay, from the lowest: compound 3; then compounds 1 and 2 (each within the scatter of the next).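

In this assay the sulfonyl sulfur does not need an aromatic ring: the ring-free 3,3,3-trifluoropropyl chain gives a lower number than either aryl group (a 4.1-fold lower number from compound 2 to compound 3 (0.61 log units; beyond the scatter) and a 2.1-fold lower number from compound 1 to compound 3 (0.32 log units; beyond the scatter)). Both steps are modest, yet they pass beyond the scatter, which the step between the two aryl groups did not. Nothing available explains this shift. As far as these compounds go, whether the fluorine atoms contribute stays open. A plain propyl chain would test that, and a longer chain would show how much length this position accepts.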